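The source may hold more compounds than are shown below. What is called first, only, known or untested is meant among the compounds shown, and "the series" means these compounds.

In an ADME assay on GM00637 cells (Homo sapiens) for cytotoxicity, read by MTT assay, with a stated time of 72 h (on this read-out lower numbers stand for stronger inhibition and higher numbers for weaker inhibition), compound 1 `O=c1ccc2nc(-c3ccccc3)nn(-c3ccccc3)c-2c1` gives 230 nM, compound 2 `CCNc1cc2nc(-c3ccccc3)nn(-c3ccccc3)c-2cc1=O` gives 240 nM and compound 3 `O=c1cc2n(-c3ccccc3)nc(-c3ccccc3)nc-2cc1N1CCCCC1` gives 1190 nM, the highest number of the three. Compound 4 `CCOc1cc2nc(-c3ccccc3)nn(-c3ccccc3)c-2cc1=O` is not yet measured and differs from compound 3 by ethoxy in place of piperidin-1-yl on an aromatic carbon. Among the compounds with values here, two measured steps bear on this change: a 5.2-fold higher number from compound 1 to compound 3 (0.71 log units; beyond the scatter) and a 5.0-fold higher number from compound 2 to compound 3 (0.70 log units; beyond the scatter), both modest and beyond the scatter, whereas a 1.0-fold higher number from compound 1 to compound 2 (0.02 log units; within the scatter) stays within it. Ethoxy holds no ring, and neither does the ethylamino of compound 2, so a return of similar size towards a lower number is expected in this assay. The expected step is a 4.0-fold lower number from compound 3 to compound 4 (0.60 log units; beyond the scatter). For compound 4 the estimated value is 300 nM, with an expected range from 110 nM to 800 nM.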

Compound 4, half-maximal inhibitory concentration: > 5000 nM
Compound 4 was reported as a limit (the forecaster's own chance of this, stated with the estimate: 3%); at least 16-fold (1.22 log units) between middle value and limit.
By their numbers in this assay, from the lowest: compounds 1 and 2 (each within the scatter of the next); then compound 3. At a limit, above all of these: compound 4.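

In this assay, ethoxy and ethylamino both hold no ring, yet they do not behave alike at this position, giving an at least 20-fold higher number from compound 2 to compound 4 (1.31 log units; beyond the scatter). Ethoxy also departs from hydrogen, with an at least 21-fold higher number from compound 1 to compound 4 (1.33 log units; beyond the scatter), and from piperidin-1-yl, with an at least 4.2-fold higher number from compound 3 to compound 4 (0.62 log units; beyond the scatter), so a ring-free group on this aromatic carbon does not by itself keep the number low. The value of compound 4 is a limit, not a number: the limit of > 5000 nM in this assay, at which 1 of the 4 values shown sits.

Going by these compounds, how far compound 4 lies beyond that limit remains open. On these data alone, it is also open whether the change follows from the oxygen or from the ethyl chain on it, which a hydroxyl, a methoxy or a propylamino group could help to separate.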